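The source may report more compounds than this note shows. Statements on the series, on what has been measured and on what is new or still open speak of the compounds shown alone.

Three compounds of the series share one core and differ only in the group on the aromatic nitrogen of the five-membered ring: compound 1 `CC(C)c1ccc(-n2nc(-c3ccccc3)nc2CNc2ccc(C(=O)NO)cc2)cc1`, compound 2 `COc1ccc(-n2nc(-c3ccccc3)nc2CNc2ccc(C(=O)NO)cc2)cc1` and compound 3 `O=C(NO)c1ccc(NCc2nc(-c3ccccc3)nn2-c2ccc(Br)cc2)cc1`. In an assay on Sf9 cells for inhibition of protein deacetylase HDAC6 (Homo sapiens), read by fluorescence, with a stated time of 40 min, tested at 100 nM (a higher number here means more inhibition at the concentration tested (going by the name of the read-out), a lower number less inhibition), compound 1 gives 52.6%, compound 2 gives 63.4% and compound 3 gives 65.9%. Compound 3 holds the highest of the three numbers; its gap to compound 2 lies within the scatter, while a number 13.3 percentage points higher from compound 1 to compound 3 (beyond the scatter) and a number 10.8 percentage points higher from compound 1 to compound 2 (beyond the scatter) lie beyond it. Compound 4 `Cc1cc(C)cc(-n2nc(-c3ccccc3)nc2CNc2ccc(C(=O)NO)cc2)c1` carries 3,5-dimethylphenyl in place of 4-bromophenyl on an aromatic nitrogen. Among the measured compounds shown here, no measured step exchanges bromo for 3,5-dimethylphenyl; the nearest guides are a number 13.3 percentage points higher from compound 1 to compound 3 (beyond the scatter), where the isopropyl compound gave the lower number, and a number 2.5 percentage points higher from compound 2 to compound 3 (within the scatter), which stays within the scatter. With a carbon-only substituent returning in compound 4, a modest fall in this assay is expected, roughly a number 10.9 percentage points lower from compound 3 to compound 4 (beyond the scatter). Compound 4 is estimated at 55%, with a range from 40% to 70%.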

Compound 4, a percentage reported as inhibition, at one concentration (the size of the read-out at that concentration, not a potency): 49.8%
Estimate against measurement, compound 4: 5.2 percentage points above, within the range that was stated.
By their numbers in this assay, from the lowest: compounds 4 and 1 (each within the scatter of the next); then compounds 2 and 3 (each within the scatter of the next).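

At the aromatic nitrogen, the change to 3,5-dimethylphenyl in this assay gives a number 16.1 percentage points lower from compound 3 to compound 4 (beyond the scatter) and a number 13.6 percentage points lower from compound 2 to compound 4 (beyond the scatter), whereas a number 2.8 percentage points lower from compound 1 to compound 4 (within the scatter). The four compounds now fall into two pairs: compound 1 and compound 4, whose substituents are carbon-only, cannot be told apart, and neither can the bromo compound 3 and the methoxy compound 2, so moving from 4-isopropylphenyl to 3,5-dimethylphenyl does not separate the carbon-only compounds. Nothing measured here accounts for this split.

Still open, as far as these compounds go, is whether the split holds for a 3,5-dimethoxyphenyl or 3,5-dibromophenyl group, or for a phenyl ring carrying an amine or a carboxylic acid. These numbers also come from a single concentration, so they give no potency for any of the four compounds.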